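Holding on to the high end in human microsomes

The source may report more compounds than this note shows. Statements on the series, on what has been measured and on what is new or still open speak of the compounds shown alone.

Compound 1 `CC(=O)N1CCN(C(=O)N2CC[C@](c3ccc(C(OCc4c(F)cccc4F)(C(F)(F)F)C(F)(F)F)cc3)(S(=O)(=O)c3ccc(F)cc3)C2)CC1` gives 5% here
Compound 2 `O=C(O)C1CCN(C(=O)N2CC[C@](c3ccc(C(OCc4c(F)cccc4F)(C(F)(F)F)C(F)(F)F)cc3)(S(=O)(=O)c3ccc(F)cc3)C2)CC1` gives 72% here
Compound 3 `O=C(O)[C@H]1CC[C@H](C(=O)N2CC[C@](c3ccc(C(OCc4ccccc4OC(F)(F)F)(C(F)(F)F)C(F)(F)F)cc3)(S(=O)(=O)c3ccc(F)cc3)C2)CC1` gives 93% here

In an ADME assay on microsomes from liver (Homo sapiens) for metabolic stability, with a stated time of 10 min (a lower number here means that less of the compound is left, a higher number that more of the compound is left), compound 3 stands highest of the three at 93% and the gaps down to compound 2 and compound 1 both lie beyond the usual scatter. The next compound, compound 4 `O=C(O)[C@H]1CC[C@H](C(=O)N2CC[C@](c3ccc(C(OCc4c(F)cccc4Cl)(C(F)(F)F)C(F)(F)F)cc3)(S(=O)(=O)c3ccc(F)cc3)C2)CC1`, differs from it by one exchange: 2-chloro-6-fluorophenyl in place of 2-(trifluoromethoxy)phenyl on a saturated chain carbon bound to an oxygen on a saturated carbon which, read one bond further out, is 2-(trifluoromethoxy)benzyl to 2-chloro-6-fluorobenzyl.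

For the measured compounds named here, only one measured step can be consulted, and it does not touch this place. It is a number 67 percentage points higher from compound 1 to compound 2 (beyond the scatter) and it is large, but it swaps the group on a carbonyl carbon, and compound 4 keeps the group of compound 3 there. Going by the values given here, no measured step isolates the exchange at hand, so the size of that large step is not carried over. The expectation rests instead on the high values of compound 3 at 93% and compound 2 at 72% in this series. The expected move is small and downward, an estimated a number 8 percentage points lower from compound 3 to compound 4 (within the scatter) and so nothing clearly beyond the scatter. Compound 4 is estimated at 85% with an expected range from 65% to 98% in this assay when measured.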

Compound 4, percent of the compound remaining: 100%
For compound 4 the middle estimate is 15 percentage points below the measured one; measured number above the stated range.
By their numbers in this assay, from the lowest: compound 1; then compound 2; then compounds 3 and 4 (each within the scatter of the next).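

In this assay, for the compounds shown here, going from 2-(trifluoromethoxy)benzyl to 2-chloro-6-fluorobenzyl gives a number 7 percentage points higher from compound 3 to compound 4 (within the scatter), the only measured step at this place, on a saturated chain carbon bound to an oxygen on a saturated carbon. The phenyl group that leaves has 11 heavy atoms and 1 hydrogen-bond acceptor, while the one that enters has 8 heavy atoms and no hydrogen-bond acceptor, yet with the rest of the molecule unchanged the read-out does not separate the two compounds, and compound 4 gives 100%. No measurement is available that would explain this result.

Since compound 3 and compound 4 both lie at the high end of the scale, the compounds shown leave open whether a benzyl group without any halogen, or one bearing a nitrile or an amine, would hold the read-out there. They also leave open whether the 2-chloro-6-fluorobenzyl group would keep this value if the carboxylic acid gave way to a primary amide, or if the 4-acetylpiperazin-1-yl group of compound 1 stood on the carbonyl carbon.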